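Loss of the aryl trifluoromethyl: compound 1 to compound 4

This account rests on a few compounds, and the source may have more. Where it says the series, first, only, none or still open, it means among the compounds named here.

Measured so far:
compound 1 `O=C(Nc1ccc(C(F)(F)F)cc1)C1CCc2ccccc2N1` gives 18600 nM in a functional assay on NUGC-3 cells (Homo sapiens) for cytotoxicity, read by sulforhodamine B assay, with a stated time of 72 h; on this read-out higher numbers stand for weaker inhibition of growth and lower numbers for stronger inhibition of growth
compound 2 `CC(=O)N1c2ccccc2CCC1C(=O)Nc1cc(C(F)(F)F)cc(C(F)(F)F)c1` gives > 70000 nM in this assay
compound 3 `O=C(Nc1cc(C(F)(F)F)cc(C(F)(F)F)c1)C1CCc2ccccc2N1` gives 8760 nM in this assay

The value of compound 2 is a limit of the assay and not a number, as shown by the limit of > 70000 nM in this assay, at which 1 of the 3 values shown sits. Among the compounds with values here, the only measured step between single-point neighbours is an at least 7.9-fold lower number from compound 2 to compound 3 (0.90 log units; beyond the scatter), which concerns the ring nitrogen and not the aryl substituent. Among the two numbers, compound 1 gives the higher one and compound 3 the lower; no step is recorded for that pair, so only the two values themselves are noted.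

Compound 4 `O=C(Nc1ccccc1)C1CCc2ccccc2N1` differs from compound 1 by hydrogen in place of trifluoromethyl on an aromatic carbon. Within the data shown here, no measured step removes a trifluoromethyl, so the acetyl step does not bear directly on it. Among the measured compounds shown here, the two numbers for compound 1 and compound 3 are the only guide: the compound with fewer trifluoromethyl groups sits higher, and compound 4 carries none. A further rise beyond the scatter in this assay is therefore expected, with a real chance that only a limit is reported.

Compound 4 is estimated at 35000 nM, within 12000 nM to 90000 nM, which is expected to mean a 1.9-fold higher number from compound 1 to compound 4 (0.27 log units; within the scatter).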

Compound 4, concentration for 50% growth inhibition: 59000 nM
Beside the measured number, compound 4's estimate is 1.7-fold (0.23 log units) below it; the range from low to high includes it.
By their numbers in this assay, from the lowest: compound 3; then compound 1; then compound 4. At a limit, above all of these: compound 2.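

Hydrogen in place of trifluoromethyl, on an aromatic carbon para to a large group, gives a 3.2-fold higher number from compound 1 to compound 4 (0.50 log units; beyond the scatter) in this assay; this is the first single-place step at this position, as the only earlier step concerned the acetyl on the ring nitrogen. The trifluoromethyl at this position therefore goes with stronger inhibition of growth, but the step is modest, and compound 4, with no trifluoromethyl, still gives a number, 59000 nM, in this assay. Compound 2 remains the only compound reported as a limit of the assay and not a number: the limit of > 70000 nM in this assay, at which 1 of the 4 values shown sits.

Whether this step is specific to trifluoromethyl remains open, since the compounds shown carry no other group at this position, such as a chlorine, a methoxy, a nitrile or a carboxylic acid. As far as these compounds go, the acetyl step also stands on a single pair of compounds, so its effect on the core of compound 1 or of compound 4, and the effect of a longer acyl chain or a methyl on that nitrogen, remain open.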